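Methoxy on the anilino ring: a second look

The source may hold more compounds than are shown below. What is called first, only, known or untested is meant among the compounds shown, and "the series" means these compounds.

Compound 1 `COc1cc(Nc2nc3ccccc3nc2S(=O)(=O)c2ccccc2)cc(OC)c1` in a functional assay on HL-60 cells (Homo sapiens) for cytotoxicity, read by MTT assay, with a stated time of 72 h (on this read-out higher numbers stand for weaker inhibition and lower numbers for stronger inhibition), gives 50 nM. Compound 2 `COc1cc(Nc2nc3ccccc3nc2S(=O)(=O)c2ccccc2)cc(OC)c1OC` gives 1770 nM in this assay, so that a 35-fold higher number from compound 1 to compound 2 (1.55 log units; beyond the scatter); the change behind it is methoxy in place of hydrogen on an aromatic carbon. Compound 3 `COc1ccc(S(=O)(=O)c2nc3ccccc3nc2Nc2ccccc2)cc1` gives 260 nM in this assay. The difference between the cores of compound 1 and compound 3 is not broken down here.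

Compound 4 `COc1ccc(Nc2nc3ccccc3nc2S(=O)(=O)c2ccc(OC)cc2)cc1` has not been measured yet. It differs from compound 3 by methoxy in place of hydrogen on an aromatic carbon. Among the measured compounds shown here, this is the same kind of change as the one from compound 1 to compound 2, but not the same: there the entering methoxy sits ortho to two methoxy groups and para to a large group, whereas in compound 4 it sits para to a large group only. The large step seen once is therefore not carried over at full size. For the measured compounds named here, a smaller weakening is expected for compound 4, a 2.3-fold higher number from compound 3 to compound 4 (0.36 log units; beyond the scatter), because a 35-fold higher number from compound 1 to compound 2 (1.55 log units; beyond the scatter) is the only measured instance and its surroundings differ. Compound 4 is expected at 600 nM in this assay, within the range 150 nM to 3000 nM.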

Compound 4, half-maximal inhibitory concentration: 1190 nM
Beside the measured number, compound 4's estimate is 2.0-fold (0.30 log units) below it; measured number inside the range.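

In this assay, methoxy in place of hydrogen on an aromatic carbon gives a weaker result on both cores, and the new instance is a 4.6-fold higher number from compound 3 to compound 4 (0.66 log units; beyond the scatter). The direction of the change held from one core to the other in these two pairs, but its size did not carry over: the same change on two cores in this assay, a 35-fold higher number (1.55 log units; beyond the scatter) from compound 1 to compound 2 and a 4.6-fold higher number (0.66 log units; beyond the scatter) from compound 3 to compound 4, 7.7-fold (0.89 log units) apart, beyond the scatter of two such steps

Two pairs do not show what sets the size of the step, and they cannot separate the surroundings of the entering methoxy from the rest of each core, so neither step can yet stand as a general value for this change across the series.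

The compounds shown leave open whether the same change on a core carrying no other methoxy would give a step nearer the smaller or the larger one. They also leave open whether another group at that place, such as an amine, a carboxylic acid or a longer alkoxy chain, would shift the number in the same direction as methoxy.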